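This account rests on a few compounds, and the source may have more. Where it says the series, first, only, none or still open, it means among the compounds named here.

Measured compounds:
Compound 1, `CC[C@H](C)[C@H](N)CN(C(=O)[C@@H]1C[C@H]1c1ccc(F)cc1)c1ccc(-c2ccccc2)cc1`, gives 600 nM in a functional assay for agonist activity at G protein-coupled receptor 88 (Homo sapiens), read by HTRF and cAMP accumulation; a higher number here means that more compound is needed for the effect, a lower number that less compound is needed.
Compound 2, `CC[C@H](C)[C@H](N)CN(C(=O)[C@@H]1C[C@H]1c1cc(F)cc(F)c1)c1ccc(-c2ccccc2)cc1`, gives 960 nM in this assay.

For the measured compounds named here, only two numbers exist here, and compound 2 cannot be separated from compound 1 on them: the step of a 1.6-fold higher number from compound 1 to compound 2 (0.20 log units; within the scatter) lies within the scatter of repeated measurements, so the two compounds stand together rather than apart.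

Compound 3, `CC[C@H](C)[C@H](N)CN(C(=O)[C@@H]1C[C@H]1c1ncccn1)c1ccc(-c2ccccc2)cc1`, is not yet measured. Its change from compound 2 is pyrimidin-2-yl in place of 3,5-difluorophenyl on a saturated ring carbon. Going by the values given here, the one measured step, a 1.6-fold higher number from compound 1 to compound 2 (0.20 log units; within the scatter), moved fluorines around on a carbon-only aromatic ring and is the only guide available; it bears on compound 3 only loosely, since here the carbon-only ring itself leaves and a ring with two nitrogen atoms enters. With so thin a basis, the expectation for compound 3 is a step of a 1.6-fold higher number from compound 2 to compound 3 (0.19 log units; within the scatter), a modestly higher number, carried mostly by uncertainty rather than by a clear precedent.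

The estimate for compound 3 in this assay is 1500 nM, with a range from 400 nM to 6000 nM.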

Compound 3, half-maximal effective concentration: 130 nM
Compound 3: middle estimate off by 12-fold (1.06 log units), on the high side, and the stated range ends above it.
By their numbers in this assay, from the lowest: compound 3; then compounds 1 and 2 (each within the scatter of the next).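

The earlier pair showed only that exchanging one fluorinated phenyl group for another on this saturated ring carbon left this assay within the scatter, so it could not show whether the aromatic ring at this position mattered at all. Replacing the carbon-only aromatic ring with pyrimidin-2-yl does separate the compounds, giving a 7.4-fold lower number from compound 2 to compound 3 (0.87 log units; beyond the scatter) and a 4.6-fold lower number from compound 1 to compound 3 (0.66 log units; beyond the scatter) in the same assay; both steps point towards less compound being needed for the effect. This position on the three-membered ring therefore responds to the kind of aromatic ring it carries, and a ring with hetero atoms is accepted there, at least in these three compounds, yet no measurement at hand explains the shift.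

The compounds shown cannot tell whether the gain depends on having pyrimidin-2-yl itself, which pyridin-2-yl, pyrimidin-5-yl or pyrazin-2-yl would begin to test. Nor can they tell whether removing the fluorines alone matters, a question that an unsubstituted phenyl group at this position would address.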